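The source may hold more compounds than are shown below. What is called first, only, known or untested is meant among the compounds shown, and "the series" means these compounds.

Measured compounds in an assay on isolated protein for agonist activity at Bile acid receptor (Homo sapiens), read by FRET; on this read-out lower numbers stand for smaller maximal responses and higher numbers for larger maximal responses:
- compound 1, `CCO[C@]1(c2ccc(OCc3c(-c4c(Cl)cccc4Cl)noc3C3CC3)cc2Cl)C[C@H](c2cccc(C(=O)O)c2)C1`: 94%
- compound 2, `CS(=O)(=O)NC(=O)c1ccc(C2CC2c2ccc(OCc3c(-c4c(Cl)cccc4Cl)noc3C3CC3)cc2Cl)cc1`: 100%
- compound 3, `O=C(O)c1cccc([C@H]2C[C@@H]2c2ccc(OCc3c(-c4c(Cl)cccc4Cl)noc3C3CC3)cc2Cl)c1`: 101%

All three share the same core and differ in the part bearing the acid or acid surrogate. In this assay compound 1 gives 94%, compound 2 gives 100% and compound 3 gives 101%. Compound 1 carries the smallest of the three numbers, but its gaps to compound 2 and to compound 3 both fall within the usual scatter, so the three are not separated by the data.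

The next compound is compound 4, `CO[C@]1(c2ccc(OCc3c(-c4c(Cl)cccc4Cl)noc3C3CC3)cc2Cl)C[C@H](c2cccc(C(=O)O)c2)C1`. It is compound 1 with a single change: hydrogen in place of methyl on a saturated chain carbon bound to an oxygen on a saturated carbon. For the measured compounds named here, no measured pair in the set shows this change, so the size of the step from compound 1 to compound 4 is not known from measurement.

Since compound 1 gives 94% and all measured members sit near full response in this assay, the change of ethoxy to methoxy is expected to leave the maximal response essentially unchanged, a step of a number 2 percentage points higher from compound 1 to compound 4 (within the scatter), well within the scatter. For compound 4 the estimated value in this assay is 96%, in the range 85% to 105%.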

Compound 4, largest response reached (reported as efficacy), in percent of the reference or control that the assay uses: 93%
Estimate against measurement, compound 4: 3 percentage points above, and the stated range covers the measured number.
By their numbers in this assay, from the lowest: compounds 4, 1, 2 and 3 (each within the scatter of the next).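

For the compounds shown here, replacing ethoxy with methoxy gives the first measured step at this position in this assay, a number 1 percentage points lower from compound 1 to compound 4 (within the scatter). The maximal response therefore does not separate the two ethers, and the ethyl group of compound 1 can give way to methyl on this core without a readable step. This holds only for this one pair and this one read-out, and no accompanying data bear on the reason for the result.

Still open, going by these compounds, is whether a longer chain such as propoxy, a branched isopropoxy or a free hydroxyl on the same saturated carbon would also stay within the scatter of compound 1 in this assay. Maximal response alone also leaves open whether the two ethers differ in any other measure.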